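The source may report more compounds than this note shows. Statements on the series, on what has been measured and on what is new or still open speak of the compounds shown alone.

Compound 1 `O=C(Nc1cccc(-n2cc(-c3ccncc3)c(-c3ccc(Cl)c(O)c3)n2)c1)Nc1cccc(C(F)(F)F)c1` joins the shared core through a urea to a 3-(trifluoromethyl)phenyl group. In a functional assay on MOLT-4 cells (Homo sapiens) for inhibition, read by sulforhodamine B assay, with a stated time of 48 h (on this read-out higher numbers stand for weaker inhibition of growth and lower numbers for stronger inhibition of growth), compound 1 gives > 32500 nM, which is a limit of the assay rather than a number. Compound 2 `O=C(Nc1cccc(-n2cc(-c3ccncc3)c(-c3ccc(Cl)c(O)c3)n2)c1)Nc1ccc(Cl)c(Cl)c1` carries 3,4-dichlorophenyl in place of 3-(trifluoromethyl)phenyl on an amide-type nitrogen. In this assay compound 2 gives > 32500 nM, again a limit. The step that the two limits leave unreadable from compound 1 to compound 2 cannot be sized because of the limit of > 32500 nM in this assay, at which 2 of the 3 values shown sit. Compound 3 `COc1cc(-c2nn(-c3cccc(NC(=O)Nc4cccc(C(F)(F)F)c4)c3)cc2-c2ccncc2)ccc1Cl` carries methyl in place of hydrogen on an oxygen on an aromatic ring, and in this assay compound 3 gives 3480 nM, giving an at least 9.3-fold lower number from compound 1 to compound 3 (0.97 log units; beyond the scatter). Compound 4 `O=C(Nc1cccc(-n2cc(-c3ccncc3)c(-c3ccc(Cl)c(O)c3)n2)c1)Nc1cc(C(F)(F)F)cc(C(F)(F)F)c1` is not yet measured and differs from compound 1 by trifluoromethyl in place of hydrogen on an aromatic carbon. Only the unreadable step between compound 1 and compound 2 touches this ring, so no direction beyond the scatter can be expected with confidence, and another limit in this assay is the likeliest outcome. Compound 4 is therefore estimated at 30000 nM, between 8000 nM and 100000 nM. This corresponds to an expected at least 1.0-fold lower number from compound 1 to compound 4 (0.03 log units; that floor lies within the scatter).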

Compound 4, concentration for total growth inhibition: 4360 nM
Beside the measured number, compound 4's estimate is 6.9-fold (0.84 log units) above it; the whole stated range lies above it.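

In this assay, for the compounds shown here, trifluoromethyl in place of hydrogen on an aromatic carbon gives an at least 7.4-fold lower number from compound 1 to compound 4 (0.87 log units; beyond the scatter), the first readable step on the phenyl ring carried by the urea. Until now, only the change on the oxygen had brought a value clear of the limit, so this ring is also a place where one small change can be read, with the hydroxyl group left in place. Going by these compounds, the true size of the step stays unknown because compound 1 has only a limit and no number: the limit of > 32500 nM in this assay, at which 2 of the 4 values shown sit.

On these data alone, whether this gain is particular to trifluoromethyl remains open, as a nitrile or an amine on the same aromatic carbon would be needed to tell. Also open, as far as these compounds go, is what the methyl on the oxygen and the added trifluoromethyl would give together in one compound.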